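The compounds below may be only part of what the source reports. "The series", "measured", "known", "first", "only" and "open" are said of these compounds alone.

Three compounds of one series have been examined in an ADME assay on NIH3T3 cells (Mus musculus) for cytotoxicity, read by CCK-8 assay, with a stated time of 24 h; on this read-out lower numbers stand for stronger inhibition and higher numbers for weaker inhibition. The series begins with compound 1 `C/C(=C\c1cc(-c2ccccc2)co1)C(N)=O`. In this assay compound 1 gives > 50000 nM, which is a limit of the assay rather than a number. Compound 2 `C/C(=C\c1cc(-c2ccc(C)cc2)cs1)C(N)=O` is the next member. In this assay compound 2 gives > 50000 nM, again a limit and not a measured number. Compound 3 `C/C(=C\c1nc(-c2ccccc2)cs1)C(N)=O` completes the measured set. In this assay compound 3 gives > 50000 nM, likewise a limit. Among the measured compounds shown here, no pair of measured compounds differs in only one place, so no measured step can be quoted. Compound 2 therefore stands exactly where every measured value stands: the limit of > 50000 nM in this assay, at which 3 of the 3 values shown sit. The compound still to be measured is compound 4 `C/C(=C\c1cc(-c2ccc(C#N)cc2)cs1)C(N)=O`. It differs from compound 2 by cyano in place of methyl on an aromatic carbon. With every measured member sitting at the limit, no step beyond the scatter is expected in this assay, in either direction. Compound 4 is accordingly expected to give about 80000 nM, within 30000 nM to 200000 nM, and most probably only a limit once more. The expected step is a step that the limit leaves unreadable from compound 2 to compound 4, nothing beyond the usual scatter.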

Compound 4, half-maximal inhibitory concentration: > 50000 nM
Compound 4 gave a limit, no number; the forecaster's own chance of this, stated with the estimate: 85%; the middle value does not contradict the limit.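

In this assay compound 4 gives > 50000 nM as a limit of the assay and not a number. Compound 2 also stands at a limit, so no step can be read from compound 2 to compound 4, and the series stays where it was: the limit of > 50000 nM in this assay, at which 4 of the 4 values shown sit. The compounds shown leave open whether cyano in place of methyl on an aromatic carbon, or any other difference among them, changes this read-out at all.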